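Swapping the Ether Chain on a Shared Core

This account rests on a few compounds, and the source may have more. Where it says the series, first, only, none or still open, it means among the compounds named here.

Two compounds share a core and differ only in the branch attached to it. Compound 1 `COCC(C)(C)Nc1nc(C)nc2c1nnn2-c1ccc(C(C)C)cc1Br` carries an amine-linked branch, and in an in vitro assay on 293-EBNA cells for binding affinity to corticotropin-releasing factor receptor 1 (Homo sapiens) (a lower number here means a stronger inhibitor, a higher number a weaker inhibitor), compound 1 gives 195 nM. Within the data shown here, compound 2 `CCC(CC)Oc1nc(C)nc2c1nnn2-c1ccc(C(C)C)cc1Br` carries an ether-linked branch instead, and in this assay compound 2 gives 1.9 nM, the lower of the two numbers; the change a 100-fold lower number from compound 1 to compound 2 (2.01 log units; beyond the scatter) is the only measured step so far. Compound 3 `CCOCC(COCC)Oc1nc(C)nc2c1nnn2-c1ccc(C(C)C)cc1Br` keeps the ether oxygen and alters what hangs on it: 2-ethoxy-1-(ethoxymethyl)ethyl in place of pentan-3-yl on an oxygen on an aromatic ring. Among the measured compounds shown here, no measured step shows what happens when one ether chain is exchanged for another that carries oxygen, so the step from compound 1 to compound 2 is not a direct guide; it only shows that this position can swing the number widely. The expectation is a modest weakening, a 3.2-fold higher number from compound 2 to compound 3 (0.50 log units; beyond the scatter), with broad uncertainty. Compound 3 is estimated at 6 nM, between 1.5 nM and 25 nM.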

Compound 3, inhibition constant: 39.7 nM
Compound 3: the middle estimate sits 6.6-fold (0.82 log units) below what was measured, and the stated range ends below it.
By their numbers in this assay, from the lowest: compound 2; then compound 3; then compound 1.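

Within the ether-linked compounds, the linking oxygen stays and only the group on it changes, yet in this assay this single exchange gives a 21-fold higher number from compound 2 to compound 3 (1.32 log units; beyond the scatter) and so shows that the result depends on the chain itself, not only on the linking atom. The oxygen-bearing chain still leaves a 4.9-fold lower number from compound 1 to compound 3 (0.69 log units; beyond the scatter) on the amine-linked compound, so only part of the drop seen with pentan-3-yl remains. Nothing on hand gives a reason for this shift.

The compounds shown leave open whether the higher number follows the two oxygens in the chain or simply its greater size, a question a longer all-carbon chain on the same oxygen would address. They also leave open how much of the earlier drop belongs to the linking atom and how much to the branch, which pentan-3-yl on an amine nitrogen would separate.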